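This account rests on a few compounds, and the source may have more. Where it says the series, first, only, none or still open, it means among the compounds named here.

Measured so far:
- compound 1, `Cc1n[nH]c2ccc(-c3nc4cnc(N5CCN(C)CC5)cn4c3Nc3ccccc3F)cc12`, in a functional assay on CWR22R cells (Homo sapiens) for inhibition, with a stated time of 120 h, tested at 10 uM (on this read-out higher numbers stand for more inhibition at the one concentration tested (going by the name of the read-out) and lower numbers for less inhibition), gives 0%
- compound 2, `Cc1n[nH]c2ccc(-c3nc4cnc(N5CCN(C)CC5)cn4c3Nc3ccc(F)cc3)cc12`, in this assay gives "not determined" (no result reported)
- compound 3, `Cc1n[nH]c2ccc(-c3nc4cnc(N5CCN(C)CC5)cn4c3Nc3ccc(F)cc3Br)cc12`, in this assay gives 4.41%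

Compound 2 therefore has no number of its own in this assay; where it stands can only be guessed from its neighbours, which both sit at the bottom of the scale. Compound 4, `Cc1n[nH]c2ccc(-c3nc4cnc(N5CCN(C)CC5)cn4c3Nc3ccc(Cl)cc3Cl)cc12`, differs from compound 2 by one change: 2,4-dichlorophenyl in place of 4-fluorophenyl on a nitrogen on an aromatic ring. Among the compounds with values here, one measured step bears on it, since it also swaps one halogen-bearing phenyl ring for another on the same nitrogen: a number 4.4 percentage points higher from compound 1 to compound 3 (within the scatter). That step left the read-out essentially where it was, near zero, so a similar exchange of halogens on that ring is expected to give no step beyond the scatter in this assay, and compound 4 is expected to sit where compounds 1 and 3 sit. Compound 4 is estimated at 3%, with a range from -5% to 15%.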

Compound 4, a percentage reported as inhibition, at one concentration (the size of the read-out at that concentration, not a potency): 9.53%
Beside the measured number, compound 4's estimate is 6.5 percentage points below it; the range from low to high includes it.
By their numbers in this assay, from the lowest: compounds 1, 3 and 4 (each within the scatter of the next).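

In this assay, putting 2,4-dichlorophenyl in place of 2-bromo-4-fluorophenyl on the nitrogen gives a number 5.1 percentage points higher from compound 3 to compound 4 (within the scatter) and putting it in place of 2-fluorophenyl gives a number 9.5 percentage points higher from compound 1 to compound 4 (within the scatter). Two chlorines on this ring therefore give a result that cannot be told apart from those of the two other halogen patterns, so three different sets of halogens now leave the read-out at the bottom of the scale. No measurement here offers a reason for this flat result.

Compound 2 has no number, so the step from it to compound 4 cannot be read. On these data alone, it remains open whether a plain phenyl ring, or a ring carrying a methoxy group, an amine or a carboxylic acid, would move the read-out at this nitrogen.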